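Methyl on the Phenolic Oxygen: Expectation for Compound 4

The source may hold more compounds than are shown below. What is called first, only, known or untested is meant among the compounds shown, and "the series" means these compounds.

Measured so far:
compound 1 `COc1cc2c(/C=C3/C(=O)Nc4ccc(O)cc43)c(Cl)n(Cc3cc(OC)c(OC)c(OC)c3)c2cc1C` — 2400 nM
compound 2 `COc1c(/C=C2/C(=O)Nc3ccccc32)c2ccccc2n1-c1ccccc1` — 2140 nM
compound 3 `O=C1Nc2ccccc2/C1=C\c1c(Cl)n(CCCc2ccccc2)c2ccccc12` — 14100 nM

Of the compounds shown here, three have been measured in a functional assay on NSCLC cells (Homo sapiens) for cytotoxicity, with a stated time of 48 h; a lower number here means a stronger inhibitor of growth, a higher number a weaker inhibitor of growth. Compound 1 gives 2400 nM, and compound 2 gives 2140 nM, a number within the scatter of that of compound 1. Compound 3 gives 14100 nM, a higher number beyond the scatter, so compound 1 stands second highest of the three. Compound 4 `COc1ccc2c(c1)/C(=C\c1c(Cl)n(Cc3cc(OC)c(OC)c(OC)c3)c3cc(C)c(OC)cc13)C(=O)N2` differs from compound 1 in one place: methyl in place of hydrogen on an oxygen on an aromatic ring. Among the compounds with values here, no pair of measured compounds differs by this change alone, so no measured step tells its size. The step from compound 1 to compound 4 in this assay is expected to be a 1.3-fold higher number from compound 1 to compound 4 (0.10 log units; within the scatter), a small one that may lie within the scatter. Compound 4 is therefore expected to give 3000 nM, between 1000 nM and 9000 nM.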

Compound 4, concentration for 50% growth inhibition: 20400 nM
Estimate against measurement, compound 4: 6.8-fold (0.83 log units) below; the measured number lies above the stated range.
By their numbers in this assay, from the lowest: compounds 2 and 1 (each within the scatter of the next); then compounds 3 and 4 (each within the scatter of the next).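

In this assay, going from hydroxy to methoxy on the aromatic ring gives an 8.5-fold higher number from compound 1 to compound 4 (0.93 log units; beyond the scatter). This is the only step among the compounds shown that isolates a single change, and it shows that this oxygen is not a silent place on the molecule: adding one methyl is enough to weaken growth inhibition beyond the scatter. Nothing available explains the size of this step. The compounds shown leave open whether the hydrogen on this oxygen is itself what counts. An amine or an ethoxy group in place of the hydroxy could separate that from the mere presence of methyl.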